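A few compounds are considered here, and "the series" means these few. Any claim that something is new, unique, unknown or untested is made for them only; others in the source may bear on it.

Of the compounds shown here, three sharing one core have been measured in an ADME assay on HEK293 cells for agonist activity at metabotropic glutamate receptor 5 (Rattus norvegicus), read by fluorescence and calcium flux; a higher number here means a larger maximal response, a lower number a smaller maximal response. Compound 1 `CC(C)[C@@H](C)NC(=O)c1ccc(C#Cc2cccc(F)c2)cn1` gives 22.5% in this assay. Compound 2 `CC(C)(C)CNC(=O)c1ccc(C#Cc2cccc(F)c2)cn1` gives 9.5%, the change being a number 13 percentage points lower from compound 1 to compound 2 (beyond the scatter). Compound 3 `O=C(NCC1CCC1)c1ccc(C#Cc2cccc(F)c2)cn1` gives 4.7%; against the first compound the change is a number 17.8 percentage points lower from compound 1 to compound 3 (beyond the scatter), whereas the change a number 4.8 percentage points lower from compound 2 to compound 3 (within the scatter) stays within the scatter. Compound 3 thus stands at the lowest number of the three, though only its gap to compound 1 is beyond the scatter.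

Compound 4 `CC(C)(O)CNC(=O)c1ccc(C#Cc2cccc(F)c2)cn1` has not yet been measured in this assay. Relative to compound 3 it carries 1-hydroxy-1-methylethyl in place of cyclobutyl on a saturated chain carbon bound to an amide-type nitrogen. The step that bears most on this change is a number 4.8 percentage points lower from compound 2 to compound 3 (within the scatter), in which one group on the same saturated chain carbon was exchanged for another with no shift beyond the scatter. The larger steps of a number 13 percentage points lower from compound 1 to compound 2 (beyond the scatter) and a number 17.8 percentage points lower from compound 1 to compound 3 (beyond the scatter) concern a different substituent on the amide-type nitrogen. Among the compounds with values here, no measured pair shows what a hydroxyl at this place does. Compound 4 is therefore expected to remain close to its predecessor. The expected step is a number 3.3 percentage points higher from compound 3 to compound 4 (within the scatter). For compound 4 the estimated maximal response is 8%, with a range from 2% to 20%.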

Compound 4, largest response reached (reported as efficacy), in percent of the reference or control that the assay uses: 20%
For compound 4 the middle estimate is 12 percentage points below the measured one; the range from low to high includes it.
By their numbers in this assay, from the lowest: compounds 3 and 2 (each within the scatter of the next); then compounds 4 and 1 (each within the scatter of the next).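

In this assay, within the data shown here, the saturated chain carbon bound to an amide-type nitrogen proves able to shift the response beyond the scatter: 1-hydroxy-1-methylethyl in place of cyclobutyl gives a number 15.3 percentage points higher from compound 3 to compound 4 (beyond the scatter) and, in the only pair that isolates a hydroxyl at this place, hydroxy in place of methyl gives a number 10.5 percentage points higher from compound 2 to compound 4 (beyond the scatter) on the chain. The earlier exchange at this carbon had shown no such shift, and here both entering and leaving groups hold 4 heavy atoms, while the entering group adds 1 hydrogen-bond donor and 1 hydrogen-bond acceptor. Among the groups on the amide-type nitrogen, 2-hydroxy-2-methylpropyl now cannot be told apart from 1,2-dimethylpropyl, with a number 2.5 percentage points lower from compound 1 to compound 4 (within the scatter) within the scatter, and no measurement given here explains the gain in response.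

Open, going by these compounds, is whether a methoxy group, a fluorine or an amine on the same saturated chain carbon would give a similar response, or whether the gain is particular to the hydroxyl. Also open, on these data alone, is what a hydroxyl would do on a longer chain, or on the 1,2-dimethylpropyl group of compound 1.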